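The source may report more compounds than this note shows. Statements on the series, on what has been measured and on what is new or still open speak of the compounds shown alone.

In a functional assay on COLO 205 cells (Homo sapiens) for antiproliferative activity, read by MTT assay, with a stated time of 68 h (on this read-out higher numbers stand for weaker inhibition and lower numbers for stronger inhibition), compound 1 `O=S(=O)(Nc1ccc(F)c(C#Cc2cnc3[nH]ncc3c2)c1F)c1cccnc1` gives 445 nM. Compound 2 `O=S(=O)(Nc1ccc(F)c(C#Cc2ccc3[nH]ncc3c2)c1F)c1cccnc1` gives > 10000 nM, which is a limit of the assay and not a number, so compound 2 stands at the weak end of the two values shown. Compound 3 `O=S(=O)(Nc1ccc(F)c(C#Cc2cnc3ccnn3c2)c1F)c1cccnc1` differs from compound 2 only in the group on a triple-bonded carbon: a group of 9 heavy atoms (6 carbon, 3 nitrogen; one five-membered aromatic ring with 2 hetero atoms, one six-membered aromatic ring with 2 hetero atoms) in place of a group of 9 heavy atoms (7 carbon, 2 nitrogen; one five-membered aromatic ring with 2 hetero atoms, one six-membered aromatic ring of carbon only), on a triple-bonded carbon. Going by the values given here, one measured step bears on this change: an at least 22-fold higher number from compound 1 to compound 2 (1.35 log units; beyond the scatter). This large step came with a six-membered aromatic ring with 1 hetero atom giving way to a six-membered aromatic ring of carbon only. The change to compound 3 goes the other way, from a six-membered aromatic ring of carbon only to a six-membered aromatic ring with 2 hetero atoms, so a sizeable move to a lower number is expected in this assay. The expected change is an at least 5.0-fold lower number from compound 2 to compound 3 (0.69 log units; beyond the scatter), towards stronger inhibition. For compound 3 the estimated value is 2000 nM, with an expected range from 450 nM to 9000 nM.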

Compound 3, half-maximal inhibitory concentration: 1840 nM
Compound 3: the middle estimate sits 1.1-fold (0.04 log units) above what was measured; the range from low to high includes it.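

In this assay, an at least 5.4-fold lower number from compound 2 to compound 3 (0.73 log units; beyond the scatter), so activity at this place on the triple-bonded carbon can return with a group that has nitrogen in both rings and 0 hydrogen-bond donors, which means a donor on this group is not needed for a measurable value. Compound 2 stands at a limit of the assay and not at a number, so that step has no upper size: the limit of > 10000 nM in this assay, at which 1 of the 3 values shown sits. The return is only partial, with a 4.1-fold higher number from compound 1 to compound 3 (0.62 log units; beyond the scatter), so two groups of the same atom count, both with three ring nitrogens, still give different results.

The compounds shown do not separate the number of ring nitrogens from their placement within the two rings. As far as these compounds go, it also remains open whether a single ring, such as pyridin-3-yl or plain phenyl, on the triple-bonded carbon would keep any of this activity.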